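Side-chain swap on a hydroxy amide inhibitor

The compounds below may be only part of what the source reports. "The series", "measured", "known", "first", "only" and "open" are said of these compounds alone.

Measured compounds:
Compound 1 `CC1(C[C@@H](O)C(=O)N2N=CC[C@H]2C(=O)NCc2cc(Cl)ccc2-n2cnnn2)CC1`, 730 nM
Compound 2 `CCCC[C@@H](O)C(=O)N1C[C@H]2C[C@H]2[C@H]1C(=O)NCc1cc(Cl)ccc1-n1cnnn1`, 750 nM

In a functional assay on a cell-free system (plasma, Homo sapiens), with a stated time of 3 min (a higher number here means a weaker inhibitor, a lower number a stronger inhibitor), compound 1 gives 730 nM, and compound 2 gives 750 nM in the same assay. The two numbers lie within the scatter of each other, so neither compound can be set apart from the other on this evidence; compound 1 simply has the lower of the two numbers shown.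

Compound 3 `CC(C)(C)OC[C@@H](O)C(=O)N1N=CC[C@H]1C(=O)NCc1cc(Cl)ccc1-n1cnnn1` has not yet been measured. It differs from compound 1 in one place: tert-butoxy in place of 1-methylcyclopropyl on a saturated chain carbon, two bonds along the chain from a carbonyl carbon and an oxygen on a saturated carbon. The rest of the structure, including the shared core and the chlorophenyl-tetrazole amide, is unchanged. Going by the values given here, no pair of measured compounds shows what such a change does in this assay, so the expectation rests on the two values alone and on the closeness of compound 1 and compound 2 despite their different side chains.

Compound 3 is therefore expected to remain close to compound 1, with a step of a 1.2-fold higher number from compound 1 to compound 3 (0.09 log units; within the scatter) that may fall within the scatter or only slightly beyond it. The estimate for compound 3 is 900 nM, within a range from 300 nM to 2700 nM.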

Compound 3, half-maximal inhibitory concentration: 750 nM
Estimate against measurement, compound 3: 1.2-fold (0.08 log units) above; measured number inside the range.
By their numbers in this assay, from the lowest: compounds 1, 2 and 3 (each within the scatter of the next).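

Going by these compounds alone, the pair gives the first reading of a change at this position: in this assay, tert-butoxy in place of 1-methylcyclopropyl, on a saturated chain carbon two bonds along the chain from a carbonyl carbon and an oxygen on a saturated carbon, gives a 1.0-fold higher number from compound 1 to compound 3 (0.01 log units; within the scatter) on the otherwise unchanged structure. The swap removes a three-membered ring of carbon only and brings in an open group with one hydrogen-bond acceptor and one more heavy atom, yet this assay does not set compound 1 and compound 3 apart. Nothing shown here offers an explanation for this result.

Whether this position accepts groups of a different kind remains open, since a side chain ending in an amine or a carboxylic acid is not among the compounds shown. Compound 2 differs from the other two in more than one place, so it cannot show whether tert-butoxy or 1-methylcyclopropyl would give a similar result on its core.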